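Phenyl in place of thiophen-3-yl: what compound 4 should show

The source may hold more compounds than are shown below. What is called first, only, known or untested is meant among the compounds shown, and "the series" means these compounds.

Of the compounds shown here, three sharing one core have been measured in a functional assay on T47D cells (Homo sapiens) for cytotoxicity, read by CCK-8 assay and cell counting, with a stated time of 2 days; a lower number here means a stronger inhibitor, a higher number a weaker inhibitor. Compound 1 `Oc1cccc(-c2cc(-c3ccc(Cl)cc3)nc(-c3cccs3)c2)c1` gives 10500 nM. Compound 2 `Oc1cccc(-c2cc(-c3ccc(Cl)cc3)nc(-c3ccsc3)c2)c1` gives 11500 nM, the highest of the three numbers, with compound 1 nearest to it and compound 3 `Oc1cccc(-c2cc(-c3ccsc3)nc(-c3cccc(Cl)c3)c2)c1` furthest, at 3540 nM. The step of a 1.1-fold higher number from compound 1 to compound 2 (0.04 log units; within the scatter) shows nothing outside the scatter, while a 3.2-fold lower number from compound 2 to compound 3 (0.51 log units; beyond the scatter) is a modest step.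

Compound 4 `Oc1cccc(-c2cc(-c3ccccc3)nc(-c3ccc(Cl)cc3)c2)c1` differs from compound 2 by phenyl in place of thiophen-3-yl on an aromatic carbon. Neither measured step touches this change directly: one exchanges thiophen-2-yl for thiophen-3-yl, the other puts 3-chlorophenyl in place of 4-chlorophenyl. The nearest guide is a 1.1-fold higher number from compound 1 to compound 2 (0.04 log units; within the scatter), which says that altering the ring in this place moved the number little, though that was a smaller change than replacing a five-membered ring with phenyl. No step beyond the scatter in this assay is therefore expected from compound 2 to compound 4, with a 1.2-fold lower number from compound 2 to compound 4 (0.06 log units; within the scatter) as the estimated step. Compound 4 is expected at 10000 nM, within 4000 nM to 25000 nM.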

Compound 4, half-maximal inhibitory concentration: 11300 nM
Beside the measured number, compound 4's estimate is 1.1-fold (0.05 log units) below it, within the range that was stated.
By their numbers in this assay, from the lowest: compound 3; then compounds 1, 4 and 2 (each within the scatter of the next).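

Phenyl in place of thiophen-3-yl gave a 1.0-fold lower number from compound 2 to compound 4 (0.01 log units; within the scatter), and phenyl in place of thiophen-2-yl gave a 1.1-fold higher number from compound 1 to compound 4 (0.03 log units; within the scatter). The earlier compounds shown here had compared only the two thiophene attachments, whereas these steps show that in this assay, with the 4-chlorophenyl group held in place, the five-membered aromatic ring with its sulfur can give way to a six-membered aromatic ring of carbon only at this place next to the ring nitrogen without a step beyond the scatter. No measurement shown here explains this result.

On these data alone, it remains open whether a non-aromatic group at this place, such as an amine or a carboxylic acid, would also leave the number within the scatter. Also open, as far as these compounds go, is whether phenyl would behave the same way alongside the 3-chlorophenyl group of compound 3.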